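A Smaller Group on the Five-Membered Ring of Compound 2

The compounds below may be only part of what the source reports. "The series", "measured", "known", "first", "only" and "open" are said of these compounds alone.

Three compounds have numbers in a functional assay on CFPAC-1 cells (Homo sapiens) for antiproliferative activity, read by MTT assay, with a stated time of 72 h; a lower number here means a stronger inhibitor, a higher number a weaker inhibitor. Compound 1 `CCCCCc1ccc(-c2cn(C/C=C3\OC(=O)C(OCc4ccccc4)=C3OCc3ccccc3)nn2)cc1` gives only a limit there, > 100000 nM. Compound 2 `CCCCCc1ccc(-c2cn(C[C@H](O)[C@H]3OC(=O)C(OCc4ccccc4)=C3OCc3ccccc3)nn2)cc1` gives 9890 nM, the lowest of the two real numbers, and compound 3 `O=C1O/C(=C\Cn2cc(-c3cccc(O)c3)nn2)C(OCc2ccccc2)=C1OCc1ccccc1` gives 33700 nM. Among the measured compounds shown here, the single measured step, an at least 2.9-fold lower number from compound 1 to compound 3 (0.47 log units; beyond the scatter), starts from that limit of > 100000 nM in this assay, at which 1 of the 3 values shown sits, and sits on a different core, so it bears only loosely on the change considered here. Compound 4 `C[Si](C)(C)c1cn(C[C@H](O)[C@H]2OC(=O)C(OCc3ccccc3)=C2OCc2ccccc2)nn1` differs from compound 2 by a group of 4 heavy atoms (3 carbon, 1 silicon; no ring) in place of a group of 11 heavy atoms (11 carbon; one six-membered aromatic ring of carbon only), on an aromatic carbon. For the measured compounds named here, with no measured step at this position in the core of compound 2, the author expects the number to rise, a 2.5-fold higher number from compound 2 to compound 4 (0.40 log units; beyond the scatter). Compound 4 is accordingly estimated at 25000 nM, with a range from 6000 nM to 100000 nM.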

Compound 4, half-maximal inhibitory concentration: 52600 nM
Compound 4: middle estimate off by 2.1-fold (0.32 log units), on the low side; the range from low to high includes it.
By their numbers in this assay, from the lowest: compound 2; then compounds 3 and 4 (each within the scatter of the next). At a limit, above all of these: compound 1.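

In this assay, among the compounds shown here, the change gives a 5.3-fold higher number from compound 2 to compound 4 (0.73 log units; beyond the scatter) and this is the first measured step at this position in the core of compound 2, with real numbers at both ends. At this aromatic carbon, the group of 4 heavy atoms with silicon and no ring therefore does not match 4-pentylphenyl. Nothing shown accounts for the size of this step. Open, going by these compounds, is how an amine or a carboxylic acid on this aromatic carbon would read. Also open, on these data alone, is whether a propyl chain in place of the pentyl chain would keep the number of compound 2.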